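Halogen placement on the benzyl group and cytotoxicity

A few compounds are considered here, and "the series" means these few. Any claim that something is new, unique, unknown or untested is made for them only; others in the source may bear on it.

Values in an ADME assay on NIH3T3 cells (Mus musculus) for cytotoxicity, with a stated time of 72 h; on this read-out higher numbers stand for weaker inhibition and lower numbers for stronger inhibition:
- compound 1 `OC[C@H]1O[C@@H](n2cnc3c(NCc4ccccc4F)ncnc32)[C@H](O)[C@@H]1O`: > 166000 nM (a limit)
- compound 2 `OC[C@H]1O[C@@H](n2cnc3c(NCc4cccc(F)c4)ncnc32)[C@H](O)[C@@H]1O`: 84000 nM
- compound 3 `OC[C@H]1O[C@@H](n2cnc3c(NCc4ccc(F)cc4)ncnc32)[C@H](O)[C@@H]1O`: 44300 nM

Compound 3 is within the scatter of compound 2, as a 1.9-fold lower number from compound 2 to compound 3 (0.28 log units; within the scatter) shows. Compound 4 `OC[C@H]1O[C@@H](n2cnc3c(NCc4ccccc4Cl)ncnc32)[C@H](O)[C@@H]1O` has 2-chlorophenyl in place of 4-fluorophenyl on a saturated chain carbon bound to a nitrogen on an aromatic ring. The closest guide is compound 1, which carries 2-fluorophenyl, through an at least 3.7-fold lower number from compound 1 to compound 3 (0.57 log units; beyond the scatter). Among the compounds with values here, no measured step exchanges fluorine for chlorine. In this assay, a higher number is therefore expected, an estimated 2.9-fold higher number from compound 3 to compound 4 (0.47 log units; beyond the scatter). A limit reading is also possible. For compound 4 the estimated value is 130000 nM, with an expected range of 55000 nM to 300000 nM.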

Compound 4, half-maximal inhibitory concentration: > 166000 nM
Compound 4: only a limit was reported; the forecaster's own chance of this, stated with the estimate: 50%; middle value at least 1.2-fold (0.10 log units) away from the limit.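

Compound 4 reads only as a limit in this assay, so 2-chlorophenyl, like 2-fluorophenyl, gives no number at this place. Against the 4-fluorophenyl compound the change gives an at least 3.7-fold higher number from compound 3 to compound 4 (0.57 log units; beyond the scatter), and against the 3-fluorophenyl compound it gives an at least 1.9-fold higher number from compound 2 to compound 4 (0.29 log units; that floor lies within the scatter). The step between compound 1 and compound 4 cannot be read, because both stop at the same limit: the limit of > 166000 nM in this assay, at which 2 of the 4 values shown sit.

From the compounds shown here alone, whether chloro in place of fluoro changes the read-out at all therefore remains open. Also open, going by these compounds, is what a methoxy group or a carboxylic acid in place of the halogen would give.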